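The source may hold more compounds than are shown below. What is called first, only, known or untested is meant among the compounds shown, and "the series" means these compounds.

For the measured compounds named here, in a functional assay on NCI-H460 cells (Homo sapiens) for inhibition, read by MTT assay, with a stated time of 72 h (on this read-out lower numbers stand for stronger inhibition and higher numbers for weaker inhibition), compound 3 `COc1cc2c(Oc3ccc(NC(=O)c4nn(-c5ccccc5C)c(=O)cc4C)cc3F)ccnc2cc1OCCCN1CCN(C)CC1` gives 3420 nM, the highest of the three numbers measured so far. Compound 1 `COc1cc2c(Oc3ccc(NC(=O)c4nn(-c5ccccc5C)c(=O)cc4C)cc3F)ccnc2cc1OCCCN1CCCC1` gives 1590 nM, and compound 2 `COc1cc2c(Oc3ccc(NC(=O)c4nn(-c5ccccc5C)c(=O)cc4C)cc3F)ccnc2cc1OCCCN1CCC(C)CC1` gives 2260 nM. Between them the steps are small: a 2.2-fold higher number from compound 1 to compound 3 (0.33 log units; beyond the scatter), while a 1.4-fold higher number from compound 1 to compound 2 (0.15 log units; within the scatter) and a 1.5-fold higher number from compound 2 to compound 3 (0.18 log units; within the scatter). Compound 3 thus sits at the weaker end, though only its gap to compound 1 is beyond the scatter.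

Compound 4 `COc1cc2c(Oc3ccc(NC(=O)c4nn(-c5ccccc5OC(F)(F)F)c(=O)cc4C)cc3F)ccnc2cc1OCCCN1CCN(C)CC1` differs from compound 3 in one place: trifluoromethoxy in place of methyl on an aromatic carbon. Going by the values given here, none of the measured steps bears on this change; all three of them alter the ring at the end of the chain and leave this aromatic carbon untouched. Among the compounds with values here, there is therefore no measured step from which to read the size or direction of the move in this assay, and the account rests on the single starting value of compound 3.

With nothing to transfer, compound 4 is expected to stay close to compound 3, and the estimate is 3400 nM, within a wide range from 1100 nM to 10000 nM. The expected step is a 1.0-fold lower number from compound 3 to compound 4 (0.00 log units; within the scatter), no more than the scatter.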

Compound 4, half-maximal inhibitory concentration: 260 nM
Compound 4: the middle estimate sits 13-fold (1.12 log units) above what was measured; the measured number lies below the stated range.
By their numbers in this assay, from the lowest: compound 4; then compounds 1, 2 and 3 (each within the scatter of the next, the first and the last beyond it).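

In this assay, for the compounds shown here, the change from 2-methylphenyl to 2-(trifluoromethoxy)phenyl gives a 13-fold lower number from compound 3 to compound 4 (1.12 log units; beyond the scatter) and so shows that this aromatic carbon, untouched in the earlier compounds, is a place where one substituent can strengthen inhibition sharply. The largest step seen at the end of the chain, a 2.2-fold higher number from compound 1 to compound 3 (0.33 log units; beyond the scatter), is far smaller, so among these compounds the group on this carbon matters more than the ring changes there. Nothing at hand accounts for the size of the new step.

The compounds shown leave open whether methoxy or trifluoromethyl on this carbon would move the number as far, which would separate the part of the oxygen from that of the fluorine atoms. Going by these compounds, it also remains open whether trifluoromethoxy brings a similar step when the chain ends in the pyrrolidin-1-yl ring of compound 1.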